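Methyl to trifluoromethyl on the aryl amide of compound 2

A few compounds are considered here, and "the series" means these few. Any claim that something is new, unique, unknown or untested is made for them only; others in the source may bear on it.

Three compounds of this series have numbers in a functional assay on HepG2 cells (Homo sapiens) for cytotoxicity, read by MTT assay, with a stated time of 72 h; on this read-out higher numbers stand for weaker inhibition and lower numbers for stronger inhibition. Compound 1 `O=C(Nc1ccc(Cl)c(Cl)c1)c1ccc(Cl)c(C(=O)Nc2ccc(-c3ncc[nH]3)nc2)c1` gives 3970 nM. Compound 2 `Cc1cc(C(=O)Nc2ccc(Cl)c(C(=O)Nc3ccc(-c4ncc[nH]4)nc3)c2)ccc1Cl` gives 11500 nM, the highest of the three numbers. Compound 3 `Cc1ccc(NC(=O)c2ccc(Cl)c(C(F)(F)F)c2)cc1C(=O)Nc1ccc(-c2ncc[nH]2)nc1` gives 6170 nM. The gap from compound 2 to compound 3 is within the scatter, so no order between these two can be read; the gap from compound 2 to compound 1 is beyond the scatter, with compound 1 at the lower number.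

Compound 4 `O=C(Nc1ccc(Cl)c(C(=O)Nc2ccc(-c3ncc[nH]3)nc2)c1)c1ccc(Cl)c(C(F)(F)F)c1` is not yet measured in this assay . It differs from compound 2 in one place: trifluoromethyl in place of methyl on an aromatic carbon. Among the measured compounds shown here, no measured pair in the set shows this same change on its own, so its size has to be guessed. Compound 3 carries a 4-chloro-3-(trifluoromethyl)phenyl group and a chloro group, as compound 4 does, but the two amides are arranged the other way round, so its value only shows that such a combination sits in the same range as the rest of the set.

With nothing more to go on, the expectation for compound 4 is a small step from compound 2, a 1.6-fold lower number from compound 2 to compound 4 (0.22 log units; within the scatter), possibly toward a lower number but not clearly beyond the scatter. Compound 4 is therefore estimated at 7000 nM, with a range from 2500 nM to 20000 nM.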

Compound 4, half-maximal inhibitory concentration: 13800 nM
For compound 4 the middle estimate is 2.0-fold (0.29 log units) below the measured one; the measured number falls inside the stated range.
By their numbers in this assay, from the lowest: compounds 1, 3, 2 and 4 (each within the scatter of the next, the first and the last beyond it).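

In this assay, the swap from 4-chloro-3-methylphenyl to 4-chloro-3-(trifluoromethyl)phenyl gives a 1.2-fold higher number from compound 2 to compound 4 (0.08 log units; within the scatter), so this first direct reading of the change at this position, ortho to a chloro group, shows no difference that can be told from the scatter, despite the larger group entering there. With the 4-chloro-3-(trifluoromethyl)phenyl group held constant, chloro in place of methyl on an aromatic carbon elsewhere in the molecule gives a 2.2-fold higher number from compound 3 to compound 4 (0.35 log units; beyond the scatter), a modest step beyond the scatter, so the series does respond to a single change at that other site on this read-out. No measurement at hand bears on the reason for either step.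

On these data alone, whether a methoxy group, an amine or a carboxylic acid at the trifluoromethyl position would shift the number beyond the scatter remains open. As far as these compounds go, it is also open whether methyl to trifluoromethyl reads the same when the other site carries methyl instead of chloro, since a single pair now stands for this change.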